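The source may report more compounds than this note shows. Statements on the series, on what has been measured and on what is new or still open speak of the compounds shown alone.

Values in a functional assay on HepG2 cells (Homo sapiens) for antiproliferative activity, read by sulforhodamine B assay, with a stated time of 3 days (on this read-out higher numbers stand for an effect only at larger amounts of compound and lower numbers for an effect already at smaller amounts), so far:

compound 1 `CCCC1=C(OCCC(C)C)C(CCC)(CCC)C(=O)/C(=C(O)\C=C\c2ccccc2)C1=O` gives 15.5 uM
compound 2 `COC1=C(CC(C)C)C(=O)/C(=C(O)/C=C/c2ccccc2)C(=O)C1(CC(C)C)CC(C)C` gives 14.5 uM
compound 3 `COC1=C(CC=C(C)C)C(=O)/C(=C(O)/C=C/c2ccccc2)C(=O)C1(CC=C(C)C)CC=C(C)C` gives 11.2 uM

Compound 1 stands with compound 2 and compound 3 inside the usual scatter of repeated measurements, so these three values give no ranking. For the measured compounds named here, the whole series so far sits in one narrow band, and compound 1 is not separated from either neighbour.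

Compound 4 `CCCOC1=C(CCC)C(=O)/C(=C(O)/C=C/c2ccccc2)C(=O)C1(CCC)CCC` has not yet been measured. It departs from compound 1 in a single place: methyl in place of isopropyl on a saturated chain carbon, two bonds along the chain from an oxygen on an unsaturated carbon. The same difference reads isopentyloxy to propoxy.

Going by the values given here, no two measured compounds differ in only one place, so no measured step bears directly on this change. Among the compounds with values here, the only guide is the band itself, with compound 2 at 14.5 uM and compound 3 at 11.2 uM lying within the scatter of compound 1 at 15.5 uM in the same read-out. In this assay the expectation is therefore no step beyond the scatter, with no direction favoured. The estimated change is a 1.1-fold lower number from compound 1 to compound 4 (0.04 log units; within the scatter) and is expected to stay within that scatter. For compound 4 the estimate is 14 uM within an expected range of 7 uM to 30 uM.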

Compound 4, concentration for half-maximal effect: 8.3 uM
For compound 4 the middle estimate is 1.7-fold (0.23 log units) above the measured one, within the range that was stated.
By their numbers in this assay, from the lowest: compounds 4, 3, 2 and 1 (each within the scatter of the next).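

For the compounds shown here, the change from isopentyloxy to propoxy provides the only step between compounds that differ in one place: in this assay, it is a 1.9-fold lower number from compound 1 to compound 4 (0.27 log units; within the scatter). On a saturated chain carbon, two bonds along the chain from an oxygen on an unsaturated carbon, methyl in place of isopropyl therefore leaves the read-out inside the scatter, with the shared core and the other chains held constant in this pair, so the isopropyl end of this chain is not shown to be needed for the activity seen in this one assay. No measurement is available that explains the size of this step or links it to any property of either group.

On these data alone, this single step covers only two saturated, uncharged chain ends at one place, so it remains open whether a longer chain, such as octyloxy, would keep the value in the same band. As far as these compounds go, it also remains open whether an amine or a carboxylic acid at the end of this chain would give a step beyond the scatter in this assay.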